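The compounds below may be only part of what the source reports. "The series", "measured", "known", "first", "only" and "open" are said of these compounds alone.

Measured so far:
compound 1, `Clc1ccc(Cc2nn3cc(-c4ccccc4)nc3s2)cc1`, > 250000 nM
compound 2, `O=[N+]([O-])c1ccc(-c2cn3nc(Cc4ccc(Cl)cc4)sc3n2)cc1`, > 250000 nM
compound 3, `O=Cc1c(-c2ccccc2)nc2sc(Cc3ccc(Cl)cc3)nn12`, 45000 nM

In a functional assay on HeLa cells (Homo sapiens) for cytotoxicity, with a stated time of 72 h (a lower number here means a stronger inhibitor, a higher number a weaker inhibitor), compound 1 gives > 250000 nM, which is a limit of the assay and not a number. Compound 2 likewise gives > 250000 nM, again a limit. Going by the values given here, compound 3 is the only member with a measured number, 45000 nM. The change formyl in place of hydrogen on an aromatic carbon gives an at least 5.5-fold lower number from compound 1 to compound 3 (0.74 log units; beyond the scatter). The change nitro in place of hydrogen on an aromatic carbon gives a step that the two limits leave unreadable from compound 1 to compound 2, because the limit of > 250000 nM in this assay, at which 2 of the 3 values shown sit, leaves nothing to read.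

Compound 4, `O=Cc1c(-c2ccc([N+](=O)[O-])cc2)nc2sc(Cc3ccc(Cl)cc3)nn12`, is to be measured in this assay. It differs from compound 3 by nitro in place of hydrogen on an aromatic carbon. This is the same change as that from compound 1 to compound 2, at a place described in the same words; the two cores differ by formyl in place of hydrogen on an aromatic carbon. Since the earlier step is unreadable, no direction is taken from it, and the step from compound 3 to compound 4 is expected to be about no change at the digits printed from compound 3 to compound 4 (within the scatter), with a wide range. Compound 4 is therefore estimated at 45000 nM, expected between 15000 nM and 150000 nM.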

Compound 4, half-maximal inhibitory concentration: 17000 nM
For compound 4 the middle estimate is 2.6-fold (0.42 log units) above the measured one, within the range that was stated.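

Carried onto the 4-nitrophenyl core, formyl in place of hydrogen on an aromatic carbon gives an at least 14-fold lower number from compound 2 to compound 4 (1.16 log units; beyond the scatter) in this assay. The direction matches that on the phenyl core, so it carries across these two cores, while the size of the change stays unsettled: the same change on two cores in this assay, an at least 5.5-fold lower number (0.74 log units; beyond the scatter) from compound 1 to compound 3 and an at least 14-fold lower number (1.16 log units; beyond the scatter) from compound 2 to compound 4; the limit leaves it open whether they differ

With formyl present, nitro in place of hydrogen on an aromatic carbon gives a 2.6-fold lower number from compound 3 to compound 4 (0.42 log units; beyond the scatter), but the same change without formyl cannot be read, so these compounds do not show whether the nitro step carries from one core to the other: the limit of > 250000 nM in this assay, at which 2 of the 4 values shown sit.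

The compounds shown leave open whether the formyl step holds when the phenyl ring carries an amine or a carboxylic acid in place of nitro. Also open, from the compounds shown here alone, is whether a carboxylic acid or a hydroxymethyl group in place of formyl would lower the number in this assay as well.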